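Swapping One Methoxypyridine Isomer for Another

A few compounds are considered here, and "the series" means these few. Any claim that something is new, unique, unknown or untested is made for them only; others in the source may bear on it.

Among the compounds with values here, compound 1 `COc1ccc(NC(=O)C(=O)c2cn(C(C)C)c3ccccc23)cn1` was tested in a functional assay on FaDu cells (Homo sapiens) for cytotoxicity, read by MTT assay, with a stated time of 72 h (on this read-out lower numbers stand for higher toxicity in this test and higher numbers for lower toxicity in this test), where compound 1 gives 85 nM, the lowest of the two numbers measured so far. Within the data shown here, its only measured neighbour is compound 2 `COc1ccc(NC(=O)C(=O)c2cn(CCOC(C)C)c3ccccc23)cn1`, which in this assay gives 211 nM; that step, a 2.5-fold higher number from compound 1 to compound 2 (0.39 log units; beyond the scatter), comes from 2-isopropoxyethyl in place of isopropyl on an aromatic nitrogen. Compound 3 `COc1cc(NC(=O)C(=O)c2cn(C(C)C)c3ccccc23)ccn1` differs from compound 1 in another part of the molecule: 2-methoxypyridin-4-yl in place of 6-methoxypyridin-3-yl on an amide-type nitrogen. Among the measured compounds shown here, no measured step touches that part, so the one known step gives no direct guide to the size or direction of the change in this assay. The same atoms are simply joined differently, and such a change may leave the number unchanged or move it either way. Compound 3 is therefore expected to give 200 nM, within a wide range from 40 nM to 1500 nM, the expected step being a 2.4-fold higher number from compound 1 to compound 3 (0.37 log units; beyond the scatter).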

Compound 3, concentration lethal to 50% of the cells: 1750 nM
Estimate against measurement, compound 3: 8.8-fold (0.94 log units) below; measured number outside the range, above it.
By their numbers in this assay, from the lowest: compound 1; then compound 2; then compound 3.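

Replacing 6-methoxypyridin-3-yl with 2-methoxypyridin-4-yl on the amide-type nitrogen keeps the same atoms and the same counts of donors and acceptors, yet in this assay it gives a 21-fold higher number from compound 1 to compound 3 (1.31 log units; beyond the scatter). This step is larger than the change on the aromatic nitrogen, a 2.5-fold higher number from compound 1 to compound 2 (0.39 log units; beyond the scatter), so among these three compounds, how the methoxypyridine is joined counts for more than the swap of isopropyl for 2-isopropoxyethyl. Nothing available here accounts for the size of the change.

Going by these compounds, it remains open whether 2-methoxypyridin-4-yl would raise the number as sharply with 2-isopropoxyethyl on the aromatic nitrogen, since compound 2 carries 6-methoxypyridin-3-yl. Also open, on these data alone, is how the number would respond if an amine or an ethoxy group replaced the methoxy group on either pyridine.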